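Amide aryl halogen scan on the shared core

A few compounds are considered here, and "the series" means these few. Any claim that something is new, unique, unknown or untested is made for them only; others in the source may bear on it.

Measured so far in an assay on cells for displacement of a labelled ligand from Neuronal acetylcholine receptor; alpha3/beta4 (Homo sapiens); on this read-out lower numbers stand for stronger inhibition and higher numbers for weaker inhibition:
compound 1 `O=C(Nc1ccccc1F)c1cncc(N2CC3CC(C2)N3)c1` gives 102 nM
compound 2 `O=C(Nc1ccc(F)cc1F)c1cncc(N2CC3CC(C2)N3)c1` gives 50 nM
compound 3 `O=C(Nc1ccccc1)c1cncc(N2CC3CC(C2)N3)c1` gives 192 nM

Compound 3 carries the bare phenyl on the amide-type nitrogen and gives the highest number of the three, though compound 1 sits within the scatter of it (a 1.9-fold higher number from compound 1 to compound 3 (0.27 log units; within the scatter)), while the gap that opens from compound 2 is real (a 3.8-fold higher number from compound 2 to compound 3 (0.58 log units; beyond the scatter)).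

Compound 4 `O=C(Nc1ccc(Cl)cc1)c1cncc(N2CC3CC(C2)N3)c1` differs from compound 3 by chloro in place of hydrogen on an aromatic carbon.

Going by the values given here, two measured steps bear on a halogen added to this aryl ring. From compound 1 to compound 2 a fluoro entering the ring lowered the number (a 2.0-fold lower number from compound 1 to compound 2 (0.31 log units; beyond the scatter)), and the step from compound 2 to compound 3 shows that stripping both fluoro groups raised it. No chloro has been tested, so the size of a chloro step is not known from these compounds; the fluoro steps suggest a modest lowering rather than none.

For compound 4 the expected step in this assay is a 2.0-fold lower number from compound 3 to compound 4 (0.31 log units; beyond the scatter), a lower number than compound 3.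

Compound 4 is therefore estimated at 95 nM, in the range 40 nM to 230 nM.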

Compound 4, inhibition constant: 123 nM
For compound 4 the middle estimate is 1.3-fold (0.11 log units) below the measured one, and the stated range covers the measured number.
By their numbers in this assay, from the lowest: compound 2; then compounds 1, 4 and 3 (each within the scatter of the next).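

In this assay, going by these compounds alone, chloro para to a large group gives no step that can be told from the scatter against the bare phenyl: a 1.6-fold lower number from compound 3 to compound 4 (0.19 log units; within the scatter). The 4-chlorophenyl also stays level with the 2-fluorophenyl, a 1.2-fold higher number from compound 1 to compound 4 (0.08 log units; within the scatter), so neither single-halogen ring shown here has a step beyond the scatter from compound 3. Within the data shown here, the 2,4-difluorophenyl stands apart from the 4-chlorophenyl, a 2.5-fold higher number from compound 2 to compound 4 (0.39 log units; beyond the scatter), and compound 2 is the only compound here whose steps to all the others lie beyond the scatter.

No evidence here accounts for these differences. Open, going by these compounds, are how 4-fluorophenyl and 2,4-dichlorophenyl would read on this amide-type nitrogen, and whether a nitrile or methoxy in place of the chloro would give a step beyond the scatter.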